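The compounds below may be only part of what the source reports. "The series", "measured", "known", "first", "only" and "open" are said of these compounds alone.

Compounds measured in a functional assay on SK-BR-3 cells (Homo sapiens) for antiproliferative activity, read by MTT assay, with a stated time of 72 h; on this read-out lower numbers stand for stronger inhibition and higher numbers for weaker inhibition:
compound 1, `CCN1CCN(c2cc(C)c3cc(NC(=O)c4cccnc4)ccc3n2)CC1`: 10600 nM
compound 2, `Cc1cc(NCCN(C)C)nc2ccc(NC(=O)c3ccc(Cl)c(Cl)c3)cc12`: 6670 nM
compound 3, `Cc1cc(N(C)C)nc2ccc(NC(=O)c3ccc(Cl)c(Cl)c3)cc12`: a limit, > 50000 nM

Compound 1 and compound 2 are the two compounds with a number in this assay, and their two values lie within the scatter of each other, so neither can be set above the other. Compound 3 returns only a limit, (the limit of > 50000 nM in this assay, at which 1 of the 3 values shown sits). Going by the values given here, the one step among the measured compounds, an at least 7.4-fold higher number from compound 2 to compound 3 (0.87 log units; beyond the scatter), concerns the substituent on the aromatic carbon of the shared core and reaches the limit.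

Compound 4, `CCN1CCN(c2cc(C)c3cc(NC(=O)c4ccccc4Br)ccc3n2)CC1`, is not yet measured. It differs from compound 1 at the amide end: 2-bromophenyl in place of pyridin-3-yl on a carbonyl carbon. Among the compounds with values here, the measured step between compound 2 and compound 3 changes a different part of the molecule and so gives no guide to this exchange; no step among the measured compounds alters the group on the carbonyl carbon. With nothing to point in either direction, a step within the scatter is expected, a 1.2-fold lower number from compound 1 to compound 4 (0.07 log units; within the scatter). Compound 4 is therefore estimated at 9000 nM in this assay, with a range from 2500 nM to 35000 nM to allow for the untested nature of this change.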

Compound 4, half-maximal inhibitory concentration: 39200 nM
For compound 4 the middle estimate is 4.4-fold (0.64 log units) below the measured one; measured number above the stated range.
By their numbers in this assay, from the lowest: compounds 2 and 1 (each within the scatter of the next); then compound 4. At a limit, above all of these: compound 3.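

In this assay, the exchange of pyridin-3-yl for 2-bromophenyl on a carbonyl carbon gives a 3.7-fold higher number from compound 1 to compound 4 (0.57 log units; beyond the scatter), so the group at the amide end does move the number, here toward weaker inhibition. Going by these compounds alone, the earlier step changed only the substituent on an aromatic carbon of the shared core, so this is the only evidence that the group on the carbonyl carbon matters while the rest of compound 1 stays the same. The exchange removes the ring nitrogen, with its one hydrogen-bond acceptor, and brings in a bromine, and no measured property shown here accounts for the step.

The compounds shown leave open whether the step follows the loss of the ring nitrogen or the entry of the bromine, a question that an unsubstituted phenyl or a bromopyridinyl group on the same carbonyl carbon would address. Also open, on these data alone, is whether the same exchange would have a similar effect in a compound carrying the (2-(dimethylamino)ethyl)amino group of compound 2 on the aromatic carbon of the shared core.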